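This account rests on a few compounds, and the source may have more. Where it says the series, first, only, none or still open, it means among the compounds named here.

In a functional assay on OVCAR-3 cells (Homo sapiens) for antiproliferative activity, read by MTT assay, with a stated time of 24 h (on this read-out higher numbers stand for weaker inhibition and lower numbers for stronger inhibition), three compounds have been measured: compound 1 `O=C(NNc1ccccc1Cl)c1ccccc1NS(=O)(=O)c1cnc(O)nc1O` gives 14100 nM, compound 2 `Cc1ccc(C(=O)NNC(=O)c2ccccc2NS(=O)(=O)c2cnc(O)nc2O)cc1` gives 12900 nM and compound 3 `O=C(NNC(=O)c1ccccc1NS(=O)(=O)c1cnc(O)nc1O)c1ccccc1Cl` gives 18200 nM. Compound 3 therefore stands within the scatter of both others, and no order can be drawn among the three. Compound 4 `O=C(NNC(=O)c1ccccc1NS(=O)(=O)c1cnc(O)nc1O)c1cccc(Cl)c1` differs from compound 3 as follows: 3-chlorophenyl in place of 2-chlorophenyl on a carbonyl carbon. The closest evidence, at the same carbonyl carbon, is a 1.4-fold higher number from compound 2 to compound 3 (0.15 log units; within the scatter). The other two steps are a 1.3-fold higher number from compound 1 to compound 3 (0.11 log units; within the scatter) and a 1.1-fold lower number from compound 1 to compound 2 (0.04 log units; within the scatter). None of these leaves the scatter, so no change beyond the scatter is expected in this assay. The estimated step is a 1.2-fold lower number from compound 3 to compound 4 (0.08 log units; within the scatter). For compound 4 the expected value is 15000 nM, with an estimated range of 8000 nM to 28000 nM.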

Compound 4, half-maximal inhibitory concentration: 2080 nM
Estimate against measurement, compound 4: 7.2-fold (0.86 log units) above, and the stated range ends above it.
By their numbers in this assay, from the lowest: compound 4; then compounds 2, 1 and 3 (each within the scatter of the next).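

In this assay this carbonyl position, which had shown no change beyond the scatter, now responds: 3-chlorophenyl in place of 2-chlorophenyl gives an 8.8-fold lower number from compound 3 to compound 4 (0.94 log units; beyond the scatter) even though the two compounds have the same atoms. The 3-chlorophenyl group also stands apart from 4-methylphenyl (a step of a 6.2-fold lower number from compound 2 to compound 4 (0.79 log units; beyond the scatter)) and from 2-chlorophenyl on the amine nitrogen (a step of a 6.8-fold lower number from compound 1 to compound 4 (0.83 log units; beyond the scatter)). Nothing measured here accounts for these differences.

On these data alone, whether a bromine, a methoxy group or an amine in place of the chlorine of 3-chlorophenyl would keep this lower number remains open. So does whether 4-chlorophenyl on the same carbonyl carbon would match it.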